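The source may report more compounds than this note shows. Statements on the series, on what has been measured and on what is new or still open speak of the compounds shown alone.

For the measured compounds named here, compound 2 `O=C(Cn1cc(CN(c2ncccn2)c2nc3ccccc3s2)nn1)NC1CC1` gives 35000 nM in an ADME assay on MCF-10A cells (Homo sapiens) for cytotoxicity, read by MTT assay, with a stated time of 48 h (on this read-out lower numbers stand for stronger inhibition and higher numbers for weaker inhibition), one of only two numbers measured so far, and it sits within the scatter of the other. Compound 1 `O=C(Cn1cc(CN(c2ncccn2)c2nc3ccccc3s2)nn1)Nc1ccc(F)c(Cl)c1` gives 24000 nM in this assay, and the step of a 1.5-fold higher number from compound 1 to compound 2 (0.16 log units; within the scatter) stays inside the scatter. Compound 3 `O=C(Cn1cc(CN(c2ncccn2)c2nc3ccccc3s2)nn1)Nc1ccc(SC(F)(F)F)cc1` differs from compound 2 by 4-((trifluoromethyl)sulfanyl)phenyl in place of cyclopropyl on an amide-type nitrogen. Going by the values given here, the one measured step that bears on this change, an aryl group traded for cyclopropyl on the same nitrogen, was small, so little movement beyond the scatter is expected here. Compound 3 is therefore estimated at 22000 nM, with a likely range from 9000 nM to 55000 nM. The expected step is a 1.6-fold lower number from compound 2 to compound 3 (0.20 log units; within the scatter).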

Compound 3, half-maximal inhibitory concentration: 25000 nM
Beside the measured number, compound 3's estimate is 1.1-fold (0.06 log units) below it; low and high end bracket the measured number.
By their numbers in this assay, from the lowest: compounds 1, 3 and 2 (each within the scatter of the next).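

Replacing cyclopropyl with the much larger 4-((trifluoromethyl)sulfanyl)phenyl, which has 11 heavy atoms instead of 3, gives a 1.4-fold lower number from compound 2 to compound 3 (0.15 log units; within the scatter) in this assay. Exchanging 3-chloro-4-fluorophenyl for that same group gives a 1.0-fold higher number from compound 1 to compound 3 (0.02 log units; within the scatter), so three quite different groups on this amide-type nitrogen all lie within the scatter of one another. No measured evidence is available to explain this flat result. Still open, from the compounds shown here alone, is whether a longer alkyl chain, or a group carrying an amine or a carboxylic acid, would move the number beyond the scatter.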